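Trading a charged sulfur group for an uncharged nitrogen one

The compounds below may be only part of what the source reports. "The series", "measured", "known", "first", "only" and "open" are said of these compounds alone.

Compound 1, `Cc1c(C)c2c(c(C)c1O)CC[C@@](C)(CC(=O)O)O2`: 17000 nM in a functional assay (brain) for inhibition, with Rattus norvegicus as the target; a lower number here means a stronger inhibitor, a higher number a weaker inhibitor
Compound 2, `Cc1c(C)c2c(c(C)c1O)CC[C@](C)(CC[S+](C)C)O2`: 2000 nM

Of the two measured compounds, compound 2 gives the lower number, and compound 1 stands higher by a gap beyond the usual scatter. Compound 3, `Cc1c(C)c2c(c(C)c1O)CC[C@](C)(CC(=O)[N-][N+](C)(C)C)O2`, is not yet measured. It differs from compound 2 in one place: a group of 7 heavy atoms (4 carbon, 2 nitrogen, 1 oxygen; no ring) in place of a group of 4 heavy atoms (3 carbon, 1 sulfur; no ring), on a saturated chain carbon bound to a saturated ring carbon. Within the data shown here, no measured pair shows a change of this kind, so its effect is open. Since compound 1, which also carries no net charge on that chain, gives 17000 nM, the step from compound 2 to compound 3 is expected to be upward, about a 3.0-fold higher number from compound 2 to compound 3 (0.48 log units; beyond the scatter). Compound 3 is estimated at 6000 nM, within 2000 nM to 20000 nM.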

Compound 3, half-maximal inhibitory concentration: 8000 nM
Beside the measured number, compound 3's estimate is 1.3-fold (0.12 log units) below it; the measured number falls inside the stated range.
By their numbers in this assay, from the lowest: compound 2; then compound 3; then compound 1.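

At this position, on a saturated chain carbon bound to a saturated ring carbon, the change gives a 4.0-fold higher number from compound 2 to compound 3 (0.60 log units; beyond the scatter) in this assay and so has a real effect. The group with net charge +1 gives the lower number of this pair, yet the uncharged group with no sulfur still gives a measurable inhibitory value. No measured evidence here bears on the reason for this step.

This single step changes net charge and group size together, and the compounds shown do not separate the two. From the compounds shown here alone, how a dimethylamino group or a longer chain bearing the same sulfur group would compare stays open.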